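The source may hold more compounds than are shown below. What is called first, only, known or untested is meant among the compounds shown, and "the series" means these compounds.

Measured compounds:
compound 1 `Cc1ccc(C(=O)Nc2cc(-c3ccccc3)nn2-c2ccccc2)cc1` — in an assay on HEK293 cells for displacement of a labelled ligand from metabotropic glutamate receptor 5 (Rattus norvegicus) (a higher number here means a weaker inhibitor, a lower number a stronger inhibitor), compound 1 gives 780 nM
compound 2 `O=C(Nc1cc(-c2ccccc2)nn1-c1ccccc1Br)c1ccccc1` — in this assay compound 2 gives 2600 nM

Compound 1 has the lowest of the two numbers; the value of compound 2 is higher, and that gap lies beyond the usual scatter. For the measured compounds named here, the two measured compounds differ in more than one place, so no single step connects them. Going by the values given here, their two values show only that compound 1 is the stronger inhibitor of the pair.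

Compound 3 `O=C(Nc1cc(-c2ccccc2)nn1-c1ccccc1)C1=CCCCC1` has not yet been measured. Compared with compound 1 it carries one change: cyclohex-1-en-1-yl in place of 4-methylphenyl on a carbonyl carbon. Among the compounds with values here, no measured step for this kind of change exists, so the expectation rests on where compound 1 stands. The expected step of a 2.1-fold higher number from compound 1 to compound 3 (0.31 log units; beyond the scatter) points toward a weaker inhibitor. Compound 3 is therefore estimated at 1600 nM, with a range from 500 nM to 5000 nM.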

Compound 3, inhibition constant: 4470 nM
For compound 3 the middle estimate is 2.8-fold (0.45 log units) below the measured one; low and high end bracket the measured number.
By their numbers in this assay, from the lowest: compound 1; then compounds 2 and 3 (each within the scatter of the next).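

Replacing 4-methylphenyl with cyclohex-1-en-1-yl on a carbonyl carbon gives a 5.7-fold higher number from compound 1 to compound 3 (0.76 log units; beyond the scatter) in this assay, the first single-place step among these compounds, and it shows that the value responds to what is attached at this position. Because the change swaps an aromatic ring for a non-aromatic one and also removes the methyl group, this one step cannot show which part of the change accounts for the higher number. No measurement shown here gives a reason for the step.

From the compounds shown here alone, it remains open whether a cyclohexyl or pyridinyl group on the carbonyl carbon would give a value nearer that of compound 1 or compound 3. The bromine of compound 2 also has no single-place step of its own among these compounds.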